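The source may hold more compounds than are shown below. What is called first, only, known or untested is meant among the compounds shown, and "the series" means these compounds.

In a functional assay on MCF7 cells (Homo sapiens) for cytotoxicity, read by sulforhodamine B assay, with a stated time of 48 h (a higher number here means a weaker inhibitor of growth, a lower number a stronger inhibitor of growth), compound 3 `ClCc1ccccc1Cn1cnc2nc(Cl)nc(Cl)c21` gives 2570 nM and compound 1 `ClCc1ccc(Cn2cnc3nc(Cl)nc(Cl)c32)cc1` gives 17000 nM, the higher number of the two. Compound 2 `ClCc1ccccc1Cn1cnc2ncnc(Cl)c21` gives only a limit of the assay, > 100000 nM. This is the limit of > 100000 nM in this assay, at which 1 of the 3 values shown sits. The step of an at least 38-fold higher number from compound 3 to compound 2 (1.59 log units; beyond the scatter) goes with hydrogen in place of chloro on an aromatic carbon, so removal of that chloro wipes out the growth inhibition seen for compound 3. Compound 1 and compound 3 are built from the same atoms joined differently; the difference between the two cores is not broken down here. Compound 4 `ClCc1ccc(Cn2cnc3ncnc(Cl)c32)cc1` is compound 1 carrying the same change, (hydrogen in place of chloro on an aromatic carbon), at a place described in identical words. Since compound 1 starts well above compound 3, a step of the same kind is expected to carry compound 4 past the upper limit, which is what a 24-fold higher number from compound 1 to compound 4 (1.37 log units; beyond the scatter) assumes. For compound 4 the expected value is 400000 nM, probably reported as a limit.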

Compound 4, concentration for total growth inhibition: 2950 nM
The estimate for compound 4 lay 140-fold (2.13 log units) above the measured number, outside the stated range (below it).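

On the core of compound 1, this assay gives a 5.8-fold lower number from compound 1 to compound 4 (0.76 log units; beyond the scatter), so hydrogen in place of chloro on an aromatic carbon does not abolish growth inhibition on this core. The change therefore does not carry over as a fixed step between the two cores: the same change on two cores in this assay, an at least 38-fold higher number (1.59 log units; beyond the scatter) from compound 3 to compound 2 and a 5.8-fold lower number (0.76 log units; beyond the scatter) from compound 1 to compound 4, at least 220-fold (2.35 log units) apart, beyond the scatter of two such steps These two pairs give no rule for other cores in the series and do not show why the steps differ.

Open, on these data alone, is how an amine or a methoxy group at that aromatic carbon would read on either core. Also open, as far as these compounds go, is what the chloro that remains in compound 4 contributes to growth inhibition.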